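Adding Bromine to a Methyl-Bearing Indole Diterpenoid Ester

This account rests on a few compounds, and the source may have more. Where it says the series, first, only, none or still open, it means among the compounds named here.

Compounds measured so far:
compound 1 `COC(=O)[C@@]1(C)CCC=C2[C@@H]1CC[C@@H](C)[C@]2(C)Cc1c[nH]c2c(Br)cccc12`: 32000 nM
compound 2 `COC(=O)[C@@]1(C)CCC=C2[C@@H]1CC[C@@H](C)[C@]2(C)Cc1c(C)[nH]c2ccccc12`: 19000 nM

In a functional assay on WiDr cells (Homo sapiens) for inhibition, read by sulforhodamine B assay, with a stated time of 48 h (a higher number here means a weaker inhibitor of growth, a lower number a stronger inhibitor of growth), compound 1 gives 32000 nM and compound 2 gives 19000 nM. Compound 2 holds the lower of the two numbers, but its gap to compound 1 lies within the scatter, so neither compound can be called the stronger. Compound 3 `COC(=O)[C@@]1(C)CCC=C2[C@@H]1CC[C@@H](C)[C@]2(C)Cc1c(C)[nH]c2c(Br)cccc12` differs from compound 2 by bromo in place of hydrogen on an aromatic carbon. Within the data shown here, compound 1 also carries a bromine, but without the methyl, so no single measured step isolates this change. The step from compound 2 to compound 3 is expected to stay within the scatter, a 1.3-fold higher number from compound 2 to compound 3 (0.12 log units; within the scatter). Compound 3 is thus estimated at 25000 nM, in the range 10000 nM to 60000 nM.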

Compound 3, concentration for 50% growth inhibition: 38000 nM
Estimate against measurement, compound 3: 1.5-fold (0.18 log units) below; the range from low to high includes it.
By their numbers in this assay, from the lowest: compounds 2, 1 and 3 (each within the scatter of the next).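

In this assay, bromo in place of hydrogen on an aromatic carbon can now be read on its own (a 2.0-fold higher number from compound 2 to compound 3 (0.30 log units; within the scatter)), and so can the gain of a methyl group (a 1.2-fold higher number from compound 1 to compound 3 (0.07 log units; within the scatter)). Neither single change separates the two compounds it links, so these compounds show no clear effect of either group. Nothing available here explains this result. Still open, on these data alone, is whether an amine or a carboxylic acid on this aromatic carbon would move the number beyond the scatter. As far as these compounds go, an ethyl group in place of the methyl remains equally open.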